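Diaryl urea series: amide nitrogen substituent and MX1 inhibition

A few compounds are considered here, and "the series" means these few. Any claim that something is new, unique, unknown or untested is made for them only; others in the source may bear on it.

Measured in a functional assay on MX1 cells (Homo sapiens) for inhibition, read by MTT assay, with a stated time of 120 h; on this read-out lower numbers stand for stronger inhibition and higher numbers for weaker inhibition:
- compound 1, `O=C(CCc1ccc(NC(=O)Nc2ccc(Cl)c(C(F)(F)F)c2)cc1)NC1CCC1`, gives 24000 nM
- compound 3, `CC(NC(=O)C#Cc1ccc(NC(=O)Nc2cc(C(F)(F)F)ccc2Cl)cc1)c1ccccc1`, gives 16100 nM
- compound 2, `C/C(=C\C(=O)NC(C)c1ccccc1)c1ccc(NC(=O)Nc2ccc(Cl)c(C(F)(F)F)c2)cc1`, reaches only the assay limit of > 50000 nM in this assay.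

Compound 1 holds the highest of the two numbers shown, but compound 3 sits within the scatter of it, so no order between the two can be read. Compound 2 gives a limit rather than a number, as noted in the limit of > 50000 nM in this assay, at which 1 of the 3 values shown sits.

Compound 4, `CNC(=O)CCc1ccc(NC(=O)Nc2ccc(Cl)c(C(F)(F)F)c2)cc1`, is the next entry in this assay. It differs from compound 1 in one place: methyl in place of cyclobutyl on an amide-type nitrogen. Among the compounds with values here, no measured pair isolates a change of this kind, so the step has no precedent here. The substituent on the amide-type nitrogen is remote from the shared core, and a step of no more than the usual scatter is expected, leaning toward a slightly higher number. The step from compound 1 to compound 4 in this assay is thus expected to be a 1.3-fold higher number from compound 1 to compound 4 (0.10 log units; within the scatter). For compound 4 the estimate in this assay is 30000 nM, between 10000 nM and 90000 nM.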

Compound 4, half-maximal inhibitory concentration: 20400 nM
Compound 4: the middle estimate sits 1.5-fold (0.17 log units) above what was measured; low and high end bracket the measured number.
By their numbers in this assay, from the lowest: compounds 3, 4 and 1 (each within the scatter of the next). At a limit, above all of these: compound 2.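

In this assay, within the data shown here, the one measured pair at this position shows a 1.2-fold lower number from compound 1 to compound 4 (0.07 log units; within the scatter), with methyl in place of cyclobutyl on the amide-type nitrogen. In this pair, going from a four-membered non-aromatic ring of 4 heavy atoms to a single carbon leaves the two numbers within the scatter of each other, so the ring is not needed to retain the value of compound 1, and compound 4 gives 20400 nM. No measured property in hand bears on this step.

Open, as far as these compounds go, is whether any group on this nitrogen moves the number beyond the scatter, such as a longer chain, a phenyl ring, or a chain ending in an amine or a carboxylic acid. Compounds 2 and 3 differ from compounds 1 and 4 in more than one place, so their steps cannot be read.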